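Adding a Methyl to the Piperidine of Compound 3

The source may report more compounds than this note shows. Statements on the series, on what has been measured and on what is new or still open speak of the compounds shown alone.

Of the compounds shown here, three with a shared core have been measured in a functional assay on HCT-116 cells (Homo sapiens) for inhibition, read by MTT assay, with a stated time of 48 h; a lower number here means a stronger inhibitor, a higher number a weaker inhibitor. Compound 2 `CCN1C(=O)CN(C2CCCC2)c2nc(Nc3ccc(N4CCN(C)CC4)cn3)ncc21` gives 16400 nM. Compound 3 `CCN1C(=O)CN(C2CCCC2)c2nc(Nc3ccc(N4CCCCC4)cn3)ncc21`, which carries a piperidin-1-yl in place of the 4-methylpiperazin-1-yl on an aromatic carbon, gives 14500 nM; the step of a 1.1-fold lower number from compound 2 to compound 3 (0.05 log units; within the scatter) lies within the scatter, so these two cannot be ordered. Among the compounds with values here, compound 1 `CC1CCN(c2ccc(Nc3ncc4c(n3)N(C3CCCC3)CC(=O)N4)nc2)CC1` has a core that differs from the one shared by compound 2 and compound 3. In this assay compound 1 reaches only a limit, > 30000 nM, which is the limit of > 30000 nM in this assay, at which 1 of the 3 values shown sits. Among the numbers shown, compound 3 holds the lowest, with compound 2 a close neighbour.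

Compound 4 `CCN1C(=O)CN(C2CCCC2)c2nc(Nc3ccc(N4CCC(C)CC4)cn3)ncc21` differs from compound 3 in one place: methyl in place of hydrogen on a saturated ring carbon, a methyl in place of hydrogen on a saturated ring carbon of a six-membered non-aromatic ring with one nitrogen, three ring bonds from the ring nitrogen. Within the data shown here, no measured step touches this change; the only step measured exchanges the whole ring and stayed within the scatter. Among the measured compounds shown here, compound 1 also bears a 4-methylpiperidin-1-yl, but its value is a limit, so it yields no step. The expected step is therefore none beyond the scatter, a 1.2-fold higher number from compound 3 to compound 4 (0.07 log units; within the scatter). Compound 4 is thus estimated at 17000 nM in this assay, between 7000 nM and 40000 nM.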

Compound 4, half-maximal inhibitory concentration: 19100 nM
Compound 4: middle estimate off by 1.1-fold (0.05 log units), on the low side, within the range that was stated.
By their numbers in this assay, from the lowest: compounds 3, 2 and 4 (each within the scatter of the next). At a limit, above all of these: compound 1.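

In this assay, within the data shown here, the methyl on a saturated ring carbon, three ring bonds from the ring nitrogen, gives the first measured step at this position: a 1.3-fold higher number from compound 3 to compound 4 (0.12 log units; within the scatter), so the number cannot be said to change when this methyl is added to the piperidine. With the methyl kept in place, exchanging the whole ring, 4-methylpiperidin-1-yl in place of 4-methylpiperazin-1-yl, gives a 1.2-fold higher number from compound 2 to compound 4 (0.07 log units; within the scatter), which shows that the earlier ring exchange also stays within the scatter in the presence of this methyl, and compounds 2, 3 and 4 cannot be ordered. For ethyl in place of hydrogen on the amide-type nitrogen, the step of an at least 1.5-fold lower number from compound 1 to compound 4 (0.19 log units; that floor lies within the scatter) is only a floor, since compound 1 sits at a limit: the limit of > 30000 nM in this assay, at which 1 of the 4 values shown sits.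

The compounds shown leave open whether another group on that same ring carbon, such as an amine, a carboxylic acid or a longer chain like butyl, would move the number beyond the scatter. Going by these compounds, the full size of the ethyl step also remains open, with only a floor to go on.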